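Replacing the 2-aminophenyl group of compound 1

A few compounds are considered here, and "the series" means these few. Any claim that something is new, unique, unknown or untested is made for them only; others in the source may bear on it.

Going by the values given here, compound 1 `Cc1cc(NC(=O)Nc2ccccc2N)c2ccccc2n1` stands highest of the two numbers so far in a physicochemical assay for solubility, at pH 7.4 (on this read-out higher numbers stand for higher solubility and lower numbers for lower solubility), where compound 1 gives 51800 nM. Compound 2 `CSc1ccccc1NC(=O)Nc1cc(C)nc2ccccc12` gives 21000 nM. Among the compounds with values here, the one measured step, a 2.5-fold lower number from compound 1 to compound 2 (0.39 log units; beyond the scatter), is modest and beyond the scatter, with methylsulfanyl in place of amino on an aromatic carbon.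

Compound 3 `Cc1cc(NC(=O)Nc2ncccc2C)c2ccccc2n1` is not yet measured and carries 3-methylpyridin-2-yl in place of 2-aminophenyl on an amide-type nitrogen. Within the data shown here, the step of a 2.5-fold lower number from compound 1 to compound 2 (0.39 log units; beyond the scatter) is the only guide, and it bears only in part: the amino group goes there too, but the rest of that aromatic ring stays. A modest drop of similar size is therefore expected in this assay, though a step within the scatter remains possible. The expected step is a 2.1-fold lower number from compound 1 to compound 3 (0.32 log units; beyond the scatter). Compound 3 is estimated at 25000 nM, with an expected range of 9000 nM to 65000 nM.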

Compound 3, solubility: 1300 nM
Estimate against measurement, compound 3: 19-fold (1.28 log units) above; measured number below the stated range.
By their numbers in this assay, from the lowest: compound 3; then compound 2; then compound 1.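

In this assay the group on this amide-type nitrogen carries more weight than the earlier pair showed: 3-methylpyridin-2-yl in place of 2-aminophenyl gives a 40-fold lower number from compound 1 to compound 3 (1.60 log units; beyond the scatter) as a large step, whereas a 2.5-fold lower number from compound 1 to compound 2 (0.39 log units; beyond the scatter) is only modest. The two compounds have the same atoms, joined differently, so a large step here needs no change in atom count; the entering group has 0 hydrogen-bond donors and the leaving group has 1. Nothing measured here accounts for the size of this step.

The compounds shown change the methyl, the ring hetero atom and the amino group together, so the share of each in the step stays open. Also open, on these data alone, is where a pyridin-2-yl without the methyl, or a phenyl carrying a carboxylic acid, would stand on this nitrogen.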